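Hydroxy to Methoxy, Repeated on a Second Core

This account rests on a few compounds, and the source may have more. Where it says the series, first, only, none or still open, it means among the compounds named here.

Of the compounds shown here, three have been measured in a functional assay on SH-SY5Y cells (Homo sapiens) for cytotoxicity, read by MTT assay, with stated times of 8 h, 30 min and 12 h, tested at 0.05 uM; a lower number here means a weaker effect, a higher number a stronger effect of the compound at the concentration tested. Compound 1 `N=C(NCc1ccc(O)cc1)[C@@H]1CCC(=O)N1Cc1ccccc1[N+](=O)[O-]` gives 20%. Compound 2 `COc1ccc(CNC(=N)[C@@H]2CCC(=O)N2Cc2ccccc2[N+](=O)[O-])cc1` gives 18.1%; it differs from compound 1 by methyl in place of hydrogen on an oxygen on an aromatic ring, and the resulting step is a number 1.9 percentage points lower from compound 1 to compound 2 (within the scatter). Compound 3 `COc1ccc(CN2C(=O)CC[C@H]2C(=N)NCc2ccc(O)cc2)cc1` gives 16%; its core differs from that of compound 1 by 4-methoxyphenyl in place of 2-nitrophenyl on a saturated chain carbon bound to an amide-type nitrogen in a ring, and the step is a number 4 percentage points lower from compound 1 to compound 3 (within the scatter). All three numbers lie within the scatter of one another, so no order among them can be read from these data.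

Compound 4 `COc1ccc(CNC(=N)[C@@H]2CCC(=O)N2Cc2ccc(OC)cc2)cc1` has not yet been measured in this assay. It differs from compound 3 by methyl in place of hydrogen on an oxygen on an aromatic ring, the same change, at the same place on an oxygen on an aromatic ring, that turns compound 1 into compound 2, now made on the core of compound 3. Because a number 1.9 percentage points lower from compound 1 to compound 2 (within the scatter) stays within the scatter, a step of similar size is expected here, namely a number 1.5 percentage points lower from compound 3 to compound 4 (within the scatter). Compound 4 is accordingly estimated at 14.5%, with a range from 6% to 24%, resting on a single prior example of this change.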

Compound 4, a percentage reported as activity, at one concentration (the size of the read-out at that concentration, not a potency): 24.2%
Estimate against measurement, compound 4: 9.7 percentage points below; measured number outside the range, above it.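

In this assay, methyl in place of hydrogen on the oxygen gives a number 8.2 percentage points higher from compound 3 to compound 4 (within the scatter), and 4-methoxyphenyl in place of 2-nitrophenyl gives a number 6.1 percentage points higher from compound 2 to compound 4 (within the scatter), so neither change is shown to have an effect on either core. The hydroxy to methoxy change is not shown to depend on the core, yet neither is it shown to carry over from one core to the other with a step of a definite size: the same change on two cores in this assay, a number 1.9 percentage points lower (within the scatter) from compound 1 to compound 2 and a number 8.2 percentage points higher (within the scatter) from compound 3 to compound 4, 10.1 percentage points apart, within the scatter of two such steps. The same reading holds for the exchange of 2-nitrophenyl for 4-methoxyphenyl: the same change on two cores in this assay, a number 4 percentage points lower (within the scatter) from compound 1 to compound 3 and a number 6.1 percentage points higher (within the scatter) from compound 2 to compound 4, 10.1 percentage points apart, within the scatter of two such steps.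

All four compounds carry only hydroxy or methoxy on that aromatic ring, which leaves open how an ethoxy group, an amine or a carboxylic acid in the same place would read. Also open, as far as these compounds go, is whether any of these steps would rise beyond the scatter at a concentration other than the single one tested.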